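Flavone series: ether chain on the phenolic oxygen

The source may hold more compounds than are shown below. What is called first, only, known or untested is meant among the compounds shown, and "the series" means these compounds.

In a functional assay for antagonist activity at Adrenergic receptor alpha-1 (Rattus norvegicus) (a lower number here means tighter binding, a higher number weaker binding), compound 1 `O=c1cc(-c2ccccc2)oc2cc(OCCCCN3CCN(c4ccccc4)CC3)ccc12` gives 4.65 nM and compound 2 `Cc1ccc(N2CCN(CCCOc3ccc4c(=O)cc(-c5ccccc5)oc4c3)CC2)cc1` gives 20.7 nM. Compound 3 `O=c1cc(-c2ccc(Cl)cc2)oc2cc(O)ccc12` gives 143 nM in this assay, the highest of the three numbers, with both gaps to compound 2 and to compound 1 beyond the scatter. Compound 4 `O=c1cc(-c2ccc(Cl)cc2)oc2cc(OCCBr)ccc12` carries 2-bromoethyl in place of hydrogen on an oxygen on an aromatic ring. Among the measured compounds shown here, no pair of measured compounds differs in one place, so the size of this step is not directly known; the two ether-bearing compounds 1 and 2 sit well below compound 3, which suggests a lower number for compound 4, though neither carries the 2-bromoethyl group. The expected step from compound 3 to compound 4 in this assay is a 1.8-fold lower number from compound 3 to compound 4 (0.25 log units; within the scatter). Compound 4 is therefore estimated at 80 nM, within 20 nM to 300 nM.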

Compound 4, dissociation constant: 119 nM
Compound 4: the middle estimate sits 1.5-fold (0.17 log units) below what was measured; measured number inside the range.
By their numbers in this assay, from the lowest: compound 1; then compound 2; then compounds 4 and 3 (each within the scatter of the next).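

Among the compounds shown here, on the oxygen on an aromatic ring, hydroxy to 2-bromoethoxy gives the first single-place step: in this assay it is a 1.2-fold lower number from compound 3 to compound 4 (0.08 log units; within the scatter) and stays within the scatter. On the core of compound 3, then, 2-bromoethyl on this oxygen leaves the number effectively unchanged. No evidence is available to account for this result.

Still open, from the compounds shown here alone, is whether a primary amine or a morpholine in place of the bromine would move the number. Going by these compounds, a longer chain on this oxygen also remains untested by any single-place step here.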